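A few compounds are considered here, and "the series" means these few. Any claim that something is new, unique, unknown or untested is made for them only; others in the source may bear on it.

The measured compounds:
Compound 1, `Nc1nc(NCc2ccccc2)c2ncn(/C=C3/CC3(CO)CO)c2n1`: in an ADME assay on MOLT-3 cells (Homo sapiens) for cytotoxicity, with a stated time of 7 days (on this read-out higher numbers stand for lower toxicity in this test and lower numbers for higher toxicity in this test), compound 1 gives > 20000 nM, a limit of the test, not a number.
Compound 2, `CC(C)Nc1nc(N)nc2c1ncn2/C=C1/CC1(CO)CO`: in this assay compound 2 gives "not determined" (no result reported), so no result was reported for it.
Compound 3, `CCCCCCSc1nc(N)nc2c1ncn2/C=C1/CC1(CO)CO`: in this assay compound 3 gives > 20000 nM, again a limit rather than a number.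

Compound 3 therefore stands at the ceiling of the test, where the limit of > 20000 nM in this assay, at which 2 of the 3 values shown sit, holds. Within the data shown here, the only measured step, a step that the two limits leave unreadable from compound 1 to compound 3, cannot be sized, as both of its ends are limits. Compound 4, `Nc1nc(SCc2ccccc2)c2ncn(/C=C3/CC3(CO)CO)c2n1`, differs from compound 3 by phenyl in place of pentyl on a saturated chain carbon bound to a sulfur. Among the measured compounds shown here, no measured step bears on this change with a readable size, so no shift beyond the scatter is expected in this assay. Compound 4 is accordingly expected at 30000 nM, within 10000 nM to 100000 nM, implying an expected step that the limit leaves unreadable from compound 3 to compound 4.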

Compound 4, half-maximal cytotoxic concentration: > 20000 nM
Compound 4 was reported as a limit (the forecaster's own chance of this, stated with the estimate: 80%); the middle value does not contradict the limit.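

The steps among compound 1, compound 3 and compound 4 cannot be read, because all three are reported only as the same limit: the limit of > 20000 nM in this assay, at which 3 of the 4 values shown sit.

The compounds shown leave open whether these three differ at all in this assay, and where compound 2 stands.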